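A few compounds are considered here, and "the series" means these few. Any claim that something is new, unique, unknown or untested is made for them only; others in the source may bear on it.

Measured compounds:
- compound 1 `CC[C@H](C)[C@H](NC(=O)N1CCC2(CC1)CN(C1CC1)C2c1ccc(Cl)cc1)C(=O)OC` — 325 nM
- compound 2 `CC[C@H](C)[C@H](NC(=O)N1CCC2(CC1)CN(c1cccc(F)c1)C2c1ccc(Cl)cc1)C(=O)OC` — 146 nM; 3200 nM (2 entries)
- compound 3 `CC[C@H](C)[C@H](NC(=O)N1CCC2(CC1)C(=O)N(c1cccc(F)c1)C2c1ccc(Cl)cc1)C(=O)NC` — 182 nM

In an assay on HEK293 cells for inhibition of Voltage-dependent T-type calcium channel subunit alpha-1H (Homo sapiens), read by patch clamp, using a membrane potential dye (a lower number here means a stronger inhibitor, a higher number a weaker inhibitor), compound 3 gives 182 nM. Compound 1, in this assay, gives 325 nM, and the two values lie within the scatter of each other, so neither can be set above the other. Compound 2 has two entries in this assay, 146 nM; 3200 nM (2 entries), which sit far apart; the spread is shown by the several entries of compound 2 in this assay, 146 nM; 3200 nM (2 entries), and it leaves compound 2 without a single number to compare with.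

Compound 4 `C[C@@H](NC(=O)N1CCC2(CC1)C(=O)N(c1cccc(F)c1)C2c1ccc(Cl)cc1)c1ccccc1` has not been measured. It differs from compound 3 in one place: 1-phenylethyl in place of 2-methyl-1-(methylcarbamoyl)butyl on an amide-type nitrogen. Among the compounds with values here, no step between measured compounds covers this change, so no measured size or direction can be borrowed for it.

For compound 4 in this assay the expectation is a value close to that of compound 3, with a step of a 1.9-fold higher number from compound 3 to compound 4 (0.28 log units; within the scatter) that may lie within the scatter or run somewhat weaker. The estimate for compound 4 is 350 nM, within a range from 90 nM to 1500 nM.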

Compound 4, half-maximal inhibitory concentration: 351 nM
Compound 4: middle estimate off by 1.0-fold (0.00 log units), on the low side; measured number inside the range.
By their numbers in this assay, from the lowest: compounds 3, 1 and 4 (each within the scatter of the next).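

In this assay, putting 1-phenylethyl in place of 2-methyl-1-(methylcarbamoyl)butyl on the amide-type nitrogen gives a 1.9-fold higher number from compound 3 to compound 4 (0.29 log units; within the scatter). Within the data shown here, this is the first measured case of an aromatic ring of carbon only in this place, and it shows that the hydrogen-bond donor, the hydrogen-bond acceptor and one of the defined stereocentres of the leaving group can all go without the number moving beyond the scatter. Nothing measured here gives a reason for this outcome.

The compounds shown leave open whether a benzyl group, a chain ending in a carboxylic acid or an amine, or the opposite configuration at the stereocentre of 1-phenylethyl would also stay within the scatter of compound 3. They also leave open whether a substituent on the phenyl ring of 1-phenylethyl would shift the number in either direction.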